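The source may report more compounds than this note shows. Statements on the series, on what has been measured and on what is new or still open speak of the compounds shown alone.

Measured compounds:
- compound 1, `O=C(/C=C/c1ccccc1)OCC1COCCOCCOCCOCCOCCO1`: 57000 nM
- compound 2, `CC(C)=CC1C(C(=O)OCC2COCCOCCOCCOCCOCCO2)C1(C)C`: 40000 nM
- compound 3, `O=C(OCC1COCCOCCOCCOCCOCCO1)c1cccnc1`: > 100000 nM

In a functional assay on HBL-100 cells (Homo sapiens) for inhibition, read by sulforhodamine B assay, with a stated time of 48 h (a higher number here means a weaker inhibitor of growth, a lower number a stronger inhibitor of growth), compound 1 gives 57000 nM and compound 2 gives 40000 nM, a gap that is a 1.4-fold lower number from compound 1 to compound 2 (0.15 log units; within the scatter). For compound 3 the value > 100000 nM is a limit of the assay, not a number. That floor is the limit of > 100000 nM in this assay, at which 1 of the 3 values shown sits. The measured steps toward it are an at least 1.7-fold higher number from compound 1 to compound 3 (0.24 log units; that floor lies within the scatter) and an at least 2.5-fold higher number from compound 2 to compound 3 (0.39 log units; beyond the scatter), so compound 3 stands at the weak end of what has been measured. Compound 4, `CC(=O)OCC1COCCOCCOCCOCCOCCO1`, differs from compound 3 by methyl in place of pyridin-3-yl on a carbonyl carbon. Going by the values given here, no measured step covers a change of this kind; the only comparisons for compound 3 end at the floor. Compound 4 is therefore expected to sit near or beyond that same floor, with the step that the limit leaves unreadable from compound 3 to compound 4 expected to be small. The estimate for compound 4 is 150000 nM, within 60000 nM to 500000 nM.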

Compound 4, concentration for 50% growth inhibition: > 100000 nM
Compound 4 ended at the assay's limit; the forecaster's own chance of this, stated with the estimate: 75%; the middle value is on the limit's open side.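

Compound 4 joins compound 3 at the limit of this assay, a limit and not a number, so the step between them cannot be read: the limit of > 100000 nM in this assay, at which 2 of the 4 values shown sit.

Putting methyl on this carbonyl carbon gives an at least 2.5-fold higher number from compound 2 to compound 4 (0.39 log units; beyond the scatter), and the comparison with the first compound gives an at least 1.7-fold higher number from compound 1 to compound 4 (0.24 log units; that floor lies within the scatter). Among the groups shown, only 2-phenylethenyl and 2,2-dimethyl-3-(2-methylprop-1-en-1-yl)cyclopropyl give a measured number.

As far as these compounds go, how far compound 3 and compound 4 lie past the limit stays open. So does whether a longer carbon chain or an amine at this place would give a measured number.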